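Amide Substituent Swap and Expected Cytotoxicity

The compounds below may be only part of what the source reports. "The series", "measured", "known", "first", "only" and "open" are said of these compounds alone.

Compound 2 `Cc1cc(C#N)cc(C)c1Oc1nc(Nc2ccc(C#N)cc2)ncc1/C=C/C(=O)NC1CCN(C(=O)C(F)(F)F)CC1` was tested in an ADME assay on TZM cells (Homo sapiens) for cytotoxicity, with a stated time of 1 days; on this read-out lower numbers stand for higher toxicity in this test and higher numbers for lower toxicity in this test. In this assay compound 2 reaches only a limit, > 170 nM. Compound 1 `C#CCNC(=O)/C=C/c1cnc(Nc2ccc(C#N)cc2)nc1Oc1c(C)cc(C#N)cc1C` likewise reaches only a limit in this assay, > 222 nM. The step that the two limits leave unreadable from compound 1 to compound 2 is therefore unreadable, as the limit of > 170 nM in this assay, at which 1 of the 2 values shown sits, and the limit of > 222 nM in this assay, at which 1 of the 2 values shown sits, show. Compound 3 `Cc1cc(C#N)cc(C)c1Oc1nc(Nc2ccc(C#N)cc2)ncc1/C=C/C(=O)NCC1CCN(S(C)(=O)=O)C1` carries (1-(methylsulfonyl)pyrrolidin-3-yl)methyl in place of 1-((trifluoromethyl)carbonyl)piperidin-4-yl on an amide-type nitrogen. Going by the values given here, the one measured change on this nitrogen gave no readable size, so no shift beyond the scatter is expected, and the step that the limit leaves unreadable from compound 2 to compound 3 is estimated as flat. Compound 3 is expected to give 200 nM, between 100 nM and 400 nM, most likely again reported only as a limit.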

Compound 3, half-maximal cytotoxic concentration: > 175 nM
Compound 3 was reported as a limit; the forecaster's own chance of this, stated with the estimate: 80%; the middle value does not contradict the limit.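

Compound 3, like compound 1 and compound 2, stands only as a limit in this assay, and the steps among these compounds cannot be read. On these data alone, the concentration at which any of them reaches half-maximal cytotoxicity stays open.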